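Amide variations on the shared core: compound 3 to compound 4

The compounds below may be only part of what the source reports. "The series", "measured", "known", "first", "only" and "open" are said of these compounds alone.

Compound 3, `COc1cc2c(cc1OC)C(CC(=O)N1CCNCC1)CC2`, stands highest of the three numbers in a functional assay on the whole organism (strain Wistar) for inhibition, with Rattus norvegicus as the target, read by paw edema, with stated times of 60 min and 3 h, at a dose of 100 mg/kg by the oral route (a higher number here means more inhibition at the dose given (going by the name of the read-out), a lower number less inhibition), giving 42%. Compound 2, `COc1cc2c(cc1OC)C(CC(=O)NC(C)(C)C)CC2`, gives 33.3%, and compound 1, `CCCNC(=O)CC1CCc2cc(OC)c(OC)cc21`, gives 29%. The step of a number 8.7 percentage points higher from compound 2 to compound 3 (within the scatter) stays within the scatter, while a number 13 percentage points higher from compound 1 to compound 3 (beyond the scatter) lies beyond it; a number 4.3 percentage points higher from compound 1 to compound 2 (within the scatter) is within the scatter.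

Compound 4, `COc1cc2c(cc1OC)C(CC(=O)N1CCOCC1)CC2`, differs from compound 3 only on a carbonyl carbon: morpholin-4-yl in place of piperazin-1-yl on a carbonyl carbon. Going by the values given here, the steps that bear on this change sit at the same carbonyl carbon, a number 13 percentage points higher from compound 1 to compound 3 (beyond the scatter) and a number 8.7 percentage points higher from compound 2 to compound 3 (within the scatter); both were small, one beyond the scatter and one within, and each replaced propylamino or (tert-butyl)amino with piperazin-1-yl. Among the compounds with values here, no measured step swaps one six-membered non-aromatic ring for another, so the expectation rests only on the small size of the changes seen at this position. A step of a number 5 percentage points lower from compound 3 to compound 4 (within the scatter) is expected, not larger than the scatter, with the direction uncertain. Compound 4 is estimated at 37%, within a range from 25% to 49%.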

Compound 4, a percentage reported as inhibition, in the whole organism at one dose (the size of the read-out at that dose, not a potency): 19.6%
Compound 4: the middle estimate sits 17.4 percentage points above what was measured; the measured number lies below the stated range.
By their numbers in this assay, from the lowest: compounds 4, 1, 2 and 3 (each within the scatter of the next, the first and the last beyond it).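

In this assay, this carbonyl carbon proves sensitive to an exchange between two six-membered non-aromatic rings of equal heavy-atom count: morpholin-4-yl in place of piperazin-1-yl gives a number 22.4 percentage points lower from compound 3 to compound 4 (beyond the scatter), a step larger than either earlier step to compound 3. Morpholin-4-yl in place of (tert-butyl)amino gives a number 13.7 percentage points lower from compound 2 to compound 4 (beyond the scatter), and in place of propylamino it gives a number 9.4 percentage points lower from compound 1 to compound 4 (within the scatter), so a six-membered ring here does not by itself carry the number of compound 3. No evidence on the origin of this step is available.

Piperazin-1-yl has a hydrogen-bond donor that morpholin-4-yl lacks, and whether this matters remains open until piperidin-1-yl or 4-methylpiperazin-1-yl is compared on the same carbonyl carbon. On these data alone, whether the step holds on any other core also remains open.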